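The source may hold more compounds than are shown below. What is called first, only, known or untested is meant among the compounds shown, and "the series" means these compounds.

Within the data shown here, in a functional assay on U-251 cells (Homo sapiens) for antiproliferative activity, read by sulforhodamine B assay, with a stated time of 48 h (on this read-out higher numbers stand for weaker inhibition of growth and lower numbers for stronger inhibition of growth), compound 1 `CCCCCC[C@@H](O)C/C=C\CCCCCCCC(=O)N[C@@H](C)c1ccccc1` gives 3.6 ug/mL and holds the lower of the two numbers so far. Compound 2 `CCCCCCCCCCCCCCCC(=O)N1CCOCC1` gives 25 ug/mL in the same read-out. That number lies beyond the scatter from compound 1, on the weaker side. Compound 3 `CCCCCC[C@@H](O)C/C=C\CCCCCCCC(=O)N1CCOCC1` keeps the core of compound 1 and takes morpholin-4-yl in place of (1-phenylethyl)amino on a carbonyl carbon. Among the measured compounds shown here, no measured pair isolates this change, so the expectation rests on thin ground. For the measured compounds named here, the one measured compound carrying morpholin-4-yl is compound 2 at 25 ug/mL and so a moderate move toward weaker inhibition of growth is expected, although a result within the scatter remains possible. The expected step is a 2.8-fold higher number from compound 1 to compound 3 (0.44 log units; beyond the scatter) in this assay and it points to a higher number. Compound 3 is estimated at 10 ug/mL (expected range 4 ug/mL to 28 ug/mL).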

Compound 3, concentration for 50% growth inhibition: 33.1 ug/mL
Estimate against measurement, compound 3: 3.3-fold (0.52 log units) below; the measured number lies above the stated range.
By their numbers in this assay, from the lowest: compound 1; then compounds 2 and 3 (each within the scatter of the next).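

In this assay the change on a carbonyl carbon can now be read with the rest of the core of compound 1 held fixed: morpholin-4-yl in place of (1-phenylethyl)amino gives a 9.2-fold higher number from compound 1 to compound 3 (0.96 log units; beyond the scatter) and so costs inhibition of growth, which the earlier pair, differing in more than one place, could not show. This single step removes the six-membered aromatic ring of carbon only, the hydrogen-bond donor and the defined stereocentre together, so it cannot assign the loss to any one of them. Nothing on hand accounts for the size of this step. Open remains whether benzylamino, which keeps the aromatic ring and the donor without the stereocentre, would stay with compound 1 or fall toward compound 3. Equally open, going by these compounds, is how piperidin-1-yl or a free carboxylic acid at this carbonyl carbon would read.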